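Sulfonyl replacement series: aryl versus benzyl on sulfur

A few compounds are considered here, and "the series" means these few. Any claim that something is new, unique, unknown or untested is made for them only; others in the source may bear on it.

Measured compounds:
compound 1 `CCOc1ccc(/C=C(/Sc2ccc(C)cc2)C(=O)c2ccc(Cl)cc2)cc1OC` gives 25000 nM in a functional assay on DU-145 cells (Homo sapiens) for inhibition, read by trypan blue exclusion, with a stated time of 96 h; a higher number here means a weaker inhibitor of growth, a lower number a stronger inhibitor of growth
compound 2 `CCOc1ccc(/C=C(\C(=O)c2ccc(Cl)cc2)S(=O)(=O)Cc2ccc(C)cc2)cc1OC` gives 10000 nM in this assay
compound 3 `CCOc1ccc(/C=C(\C(=O)c2ccc(Cl)cc2)S(=O)(=O)c2ccc(C)cc2)cc1OC` gives 1000 nM in this assay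

Compound 3 holds the lowest number of the three. The change to compound 4 `CCOc1ccc(/C=C(\C(=O)c2ccc(Cl)cc2)S(=O)(=O)Cc2ccccc2Cl)cc1OC` is 2-chlorobenzyl in place of 4-methylphenyl on a sulfonyl sulfur. The step that bears on it is a 10-fold lower number from compound 2 to compound 3 (1.00 log units; beyond the scatter), a benzyl-to-aryl exchange on the same sulfur; compound 4 returns to a benzyl attached to the sulfonyl sulfur, so a step of similar size in the opposite direction is expected, an 8.0-fold higher number from compound 3 to compound 4 (0.90 log units; beyond the scatter). The wider context, a 25-fold lower number from compound 1 to compound 3 (1.40 log units; beyond the scatter), shows that the sulfonyl itself is kept in compound 4. Compound 4 is therefore estimated at 8000 nM, within a range from 2500 nM to 25000 nM.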

Compound 4, concentration for 50% growth inhibition: 10000 nM
The estimate for compound 4 lay 1.3-fold (0.10 log units) below the measured number; the measured number falls inside the stated range.
By their numbers in this assay, from the lowest: compound 3; then compounds 2 and 4 (each within the scatter of the next); then compound 1.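

In this assay, the return to a benzyl type of group on the sulfonyl sulfur gives a clear loss against 4-methylphenyl (a 10-fold higher number from compound 3 to compound 4 (1.00 log units; beyond the scatter)), so the gap seen with 4-methylbenzyl also holds for 2-chlorobenzyl. Exchanging 4-methylphenyl for 2-chlorophenyl on the saturated chain carbon does not separate the two benzyl compounds (no change at the digits printed from compound 2 to compound 4 (within the scatter)). The sulfonyl with 2-chlorobenzyl keeps only a modest gain over the sulfanyl compound (a 2.5-fold lower number from compound 1 to compound 4 (0.40 log units; beyond the scatter)). No measured evidence bears on why these steps take this size. Still open, going by these compounds, is how an unsubstituted benzyl, a longer chain or an amine on the sulfonyl sulfur would read here.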